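Bromo in place of methoxy, starting from an assay limit

This account rests on a few compounds, and the source may have more. Where it says the series, first, only, none or still open, it means among the compounds named here.

In a functional assay on MT4 cells (Homo sapiens) for cytotoxicity (on this read-out lower numbers stand for stronger inhibition and higher numbers for weaker inhibition), compound 1 (`N#Cc1c(N)cccc1Sc1cccc(Cl)c1`) gives 53000 nM. Compound 3 (`N#Cc1c(N)cccc1[S+]([O-])c1ccccc1Br`) gives 168000 nM in this assay. Compound 2 (`COc1ccc([S+]([O-])c2cccc(N)c2C#N)cc1`) stands at the end of the scale, where this assay reports for compound 2 only a limit, > 200000 nM. Its true value is therefore not known, and no measured step between any of these compounds is available as a guide.

Compound 4 (`N#Cc1c(N)cccc1[S+]([O-])c1ccc(Br)cc1`) changes one place on compound 2: bromo in place of methoxy on an aromatic carbon. This puts bromo in place of methoxy on an aromatic carbon, para to a large group. The closest reference is compound 3, which also carries a bromo group and gives 168000 nM. On that basis, a small move towards lower numbers in this assay is expected, not clearly beyond the scatter: an at least 1.4-fold lower number from compound 2 to compound 4 (0.15 log units; that floor lies within the scatter). Compound 4 may also return only a limit. The estimate for compound 4 is 140000 nM, with an expected range from 65000 nM to 280000 nM.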

Compound 4, half-maximal inhibitory concentration: > 200000 nM
Compound 4: no number, only a limit; the forecaster's own chance of this, stated with the estimate: 35%; middle value at least 1.4-fold (0.15 log units) away from the limit.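

Going by these compounds alone, compound 2 and compound 4 both return only a limit in this assay, so no step between them can be read. The compounds shown leave open whether bromo in place of methoxy on an aromatic carbon changes this read-out at all, and in which direction.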